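This account rests on a few compounds, and the source may have more. Where it says the series, first, only, none or still open, it means among the compounds named here.

Working notes on the series. Within the data shown here, compound 1 `COc1cc(/C=C/C(=O)c2cccc(-n3cc(-c4ccc(Cl)cc4)[nH]c3=O)c2)cc(OC)c1OC` is the only member with a number: in a functional assay on NCI-H522 cells (Homo sapiens) for inhibition (on this read-out higher numbers stand for weaker inhibition of growth and lower numbers for stronger inhibition of growth), compound 1 gives 4100 nM. Compound 2 `O=C(/C=C/c1cccc(O)c1)c1cccc(-n2cc(-c3ccccc3)[nH]c2=O)c1` belongs to the same set, but in this assay compound 2 carries "not determined" (no result reported), so it gives no bearing on where compound 1 stands. Within the numbers shown, compound 1 therefore stands alone, with nothing to rank it against.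

Compound 3 `COc1cc(/C=C/C(=O)c2cccc(-n3cc(-c4ccccc4)[nH]c3=O)c2)cc(OC)c1OC` is the next entry for this assay. It differs from compound 1 in one place: hydrogen in place of chloro on an aromatic carbon. Among the measured compounds shown here, no pair with a number on both sides shows a change of this kind, so the size of the step rests on the change alone.

The step from compound 1 to compound 3 in this assay is expected to be small, a 1.2-fold higher number from compound 1 to compound 3 (0.09 log units; within the scatter), and likely within the usual scatter, with no clear direction. Compound 3 is accordingly estimated at 5000 nM in this assay, within a range from 1500 nM to 15000 nM.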

Compound 3, concentration for 50% growth inhibition: 950 nM
Estimate against measurement, compound 3: 5.3-fold (0.72 log units) above; measured number below the stated range.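

In this assay, among these compounds, the 4-chlorophenyl to phenyl change gives the first readable step, a 4.3-fold lower number from compound 1 to compound 3 (0.64 log units; beyond the scatter), so what sits on this aromatic carbon, para to a large group, does register in the read-out. The lower number lies with the hydrogen, which shows that the chloro is not required for the growth inhibition seen with this core and that compound 3 is the better of this single pair. No measured evidence on hand bears on the reason for this step.

As far as these compounds go, the finding rests on one pair, so it remains open whether the trend reflects the loss of chloro specifically or would hold for other groups at this place, such as fluoro, an amine or a carboxylic acid. From the compounds shown here alone, it is also open whether the same step would appear on a different substitution pattern at the other end of the molecule, since the hydroxyphenyl compound 2 has no number to set beside compound 3 in this assay.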